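Notes on the step from compound 3 to compound 4

The compounds below may be only part of what the source reports. "The series", "measured", "known", "first", "only" and "open" are said of these compounds alone.

compound 1 `O=C(NCc1ccccc1Br)N1C(=O)c2ccccc2S1(=O)=O` gives 0.253 h
compound 2 `O=C(NCc1ccccc1F)N1C(=O)c2ccccc2S1(=O)=O` gives 0.598 h
compound 3 `O=C(NCC1CCCCC1)N1C(=O)c2ccccc2S1(=O)=O` gives 0.963 h

In a physicochemical assay for pharmacokinetics (on this read-out higher numbers stand for a longer-lived compound and lower numbers for a shorter-lived compound), compound 3 gives 0.963 h. The series shows a 1.6-fold higher number from compound 2 to compound 3 (0.21 log units; within the scatter) and a 3.8-fold higher number from compound 1 to compound 3 (0.58 log units; beyond the scatter), so this compound stands level with one aromatic analogue and clear of the other.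

Compound 4 `COc1ccccc1CNC(=O)N1C(=O)c2ccccc2S1(=O)=O` carries one change, (2-methoxyphenyl in place of cyclohexyl on a saturated chain carbon bound to an amide-type nitrogen), namely 2-methoxyphenyl in place of cyclohexyl on a saturated chain carbon bound to an amide-type nitrogen. The two steps above are the closest guide, read in reverse, and a 2.4-fold higher number from compound 1 to compound 2 (0.37 log units; beyond the scatter) shows that the aromatic substituent can move the number. Among the measured compounds shown here, no methoxy analogue has been measured, so the size remains uncertain. With compound 2 at 0.598 h as the nearer aromatic reference, a small fall is expected, not clearly beyond the scatter. The expected step is a 1.9-fold lower number from compound 3 to compound 4 (0.28 log units; within the scatter) on this basis. Compound 4 is estimated at 0.5 h, with an expected range from 0.22 h to 1 h.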

Compound 4, half-life: 1.12 h
Estimate against measurement, compound 4: 2.2-fold (0.35 log units) below, outside the stated range (above it).
By their numbers in this assay, from the lowest: compound 1; then compounds 2, 3 and 4 (each within the scatter of the next).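

In this assay, the step of a 1.2-fold higher number from compound 3 to compound 4 (0.07 log units; within the scatter) puts 2-methoxyphenyl level with cyclohexyl on a saturated chain carbon bound to an amide-type nitrogen, so a saturated and an aromatic ring can give matching numbers at this place, although compound 1 goes against any general match. The aromatic substituent still matters only in part: methoxy in place of fluoro gives a 1.9-fold higher number from compound 2 to compound 4 (0.27 log units; within the scatter) and stays level, whereas methoxy in place of bromo gives a 4.4-fold higher number from compound 1 to compound 4 (0.65 log units; beyond the scatter) and leaves compound 1 apart from compound 4. Nothing on hand accounts for these steps.

As far as these compounds go, whether the half-life can be carried clear of this level remains open. A carboxylic acid or an amine in place of methoxy, or a longer chain in place of the single saturated carbon, would test that.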